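Sulfonyl aryl variation on a shared quinazoline-free core series

The source may hold more compounds than are shown below. What is called first, only, known or untested is meant among the compounds shown, and "the series" means these compounds.

Compound 1 `COc1cc2nc(N3CCN(S(=O)(=O)c4ccc(Br)cc4)CC3)nc(N)c2cc1OC` sits at the lowest number of the three measured in a functional assay on PC-3 cells (Homo sapiens) for inhibition (a higher number here means a weaker inhibitor, a lower number a stronger inhibitor), giving 20000 nM. Compound 2 `COc1cc2nc(N3CCN(S(=O)(=O)c4cc(Cl)ccc4Cl)CC3)nc(N)c2cc1OC` gives 60000 nM and compound 3 `COc1cc2nc(N3CCN(S(=O)(=O)c4cc(F)c(Cl)c(C(=O)O)c4)CC3)nc(N)c2cc1OC` gives 56000 nM in this assay. Both departures from compound 1 raised the number: a 3.0-fold higher number from compound 1 to compound 2 (0.48 log units; beyond the scatter) and a 2.8-fold higher number from compound 1 to compound 3 (0.45 log units; beyond the scatter), while a 1.1-fold lower number from compound 2 to compound 3 (0.03 log units; within the scatter). Compound 4 `COc1cc2nc(N3CCN(S(=O)(=O)c4ccc(-c5ccc(C(F)(F)F)cc5)cc4)CC3)nc(N)c2cc1OC` differs from compound 1 by 4-(trifluoromethyl)phenyl in place of bromo on an aromatic carbon. Among the measured compounds shown here, no measured step adds a ring to the sulfonyl aryl group, so the measured steps bear only indirectly: every change away from compound 1 so far gave a modestly higher number, and no change yet lowered it. Compound 4 is therefore expected to give about 30000 nM in this assay, within 8000 nM to 100000 nM, a step of a 1.5-fold higher number from compound 1 to compound 4 (0.18 log units; within the scatter) with wide uncertainty in either direction.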

Compound 4, half-maximal inhibitory concentration: 3300 nM
Beside the measured number, compound 4's estimate is 9.1-fold (0.96 log units) above it; the measured number lies below the stated range.
By their numbers in this assay, from the lowest: compound 4; then compound 1; then compounds 3 and 2 (each within the scatter of the next).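

In this assay, among the compounds shown here, 4-(trifluoromethyl)phenyl in place of bromo gives a 6.1-fold lower number from compound 1 to compound 4 (0.78 log units; beyond the scatter) and is the only change away from compound 1 so far to lower the number. This position, para to a large group, therefore tolerates a second six-membered aromatic ring, which the earlier sulfonyl aryl changes did not test. No evidence at hand bears on the reason for this result.

Going by these compounds, whether the gain comes from the added ring or from its trifluoromethyl group stays open. An unsubstituted phenyl, or an added ring carrying an amine or a methoxy group, would separate the two.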